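Phenol for methoxyphenyl on a shared antiproliferative core

The source may report more compounds than this note shows. Statements on the series, on what has been measured and on what is new or still open speak of the compounds shown alone.

Measured compounds:
Compound 1, `C=CC[C@H]1C[C@]2([C@@H](C)Cc3ccc(OC)c(OC)c3)OCOC2=CC1=O`: 110 nM
Compound 2, `C=CC[C@H]1C[C@]2([C@@H](C)Cc3cccc(OC)c3)OCOC2=CC1=O`: 8800 nM

In a functional assay on M14 cells (Homo sapiens) for antiproliferative activity, with a stated time of 72 h (on this read-out lower numbers stand for stronger inhibition and higher numbers for weaker inhibition), compound 1 gives 110 nM and compound 2 gives 8800 nM. Among the compounds with values here, compound 2 stands at the higher of the two numbers, the step of an 80-fold higher number from compound 1 to compound 2 (1.90 log units; beyond the scatter) being the only measured step.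

Compound 3, `C=CC[C@H]1C[C@]2([C@@H](C)Cc3ccc(O)cc3)OCOC2=CC1=O`, has not yet been measured. It differs from compound 2 by 4-hydroxyphenyl in place of 3-methoxyphenyl on a saturated chain carbon, two bonds along the chain from a saturated ring carbon. Within the data shown here, the single measured step bears on this only indirectly: it shows that taking one methoxy group off the aromatic ring of compound 1 brought a large loss, an 80-fold higher number from compound 1 to compound 2 (1.90 log units; beyond the scatter), and compound 3 carries neither of the two methoxy groups of compound 1. Among the measured compounds shown here, the data hold no step that tells how a hydroxy group on the aromatic ring behaves. Compound 3 is therefore expected to stay close to compound 2 in this assay, with a step of a 1.3-fold lower number from compound 2 to compound 3 (0.10 log units; within the scatter), which could fall on either side of the scatter. For compound 3 the estimate in this assay is 7000 nM, with a range from 1500 nM to 30000 nM.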

Compound 3, half-maximal inhibitory concentration: > 20000 nM
Compound 3: only a limit was reported; the forecaster's own chance of this, stated with the estimate: 10%; middle value at least 2.8-fold (0.45 log units) from the limit.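

Within the data shown here, replacing 3-methoxyphenyl with 4-hydroxyphenyl on a saturated chain carbon, two bonds along the chain from a saturated ring carbon, gives in this assay an at least 2.2-fold higher number from compound 2 to compound 3 (0.35 log units; beyond the scatter), which is the first measured step at this position that involves a hydroxy group on the aromatic ring. For compound 3 the reading is a limit of the assay and not a number, so this step gives only a minimum size: the limit of > 20000 nM in this assay, at which 1 of the 3 values shown sits. The earlier compounds shown here showed only that this position responds strongly to the loss of one methoxy group, as in an 80-fold higher number from compound 1 to compound 2 (1.90 log units; beyond the scatter), whereas compound 3 adds that a single hydroxy group on the ring, in a compound without either methoxy group of compound 1, does not bring back the stronger inhibition and goes further from it than compound 2 does.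

The change from compound 2 to compound 3 alters both the kind of oxygen group and its place on the aromatic ring, and the compounds shown cannot separate these two changes. Going by these compounds, it also stays open how this assay would respond to a different group on that ring, such as an amine or a carboxylic acid, or to a longer chain between the ring and the shared core.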